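This account rests on a few compounds, and the source may have more. Where it says the series, first, only, none or still open, it means among the compounds named here.

Measured compounds: compound 1 `O=C(CCCCC[C@H](NC(=O)[C@@H]1CCCC(=O)N1)C(=O)Nc1ccccc1)NO`, 97 nM; compound 2 `O=C(CCCCC[C@H](NC(=O)C1CCCNC1=O)C(=O)Nc1ccccc1)NO`, 251 nM.

Compound 2 gives the highest of the two numbers in an assay on isolated protein for inhibition of histone deacetylase 8 (Homo sapiens), read by fluorescence; a lower number here means a stronger inhibitor, a higher number a weaker inhibitor; its nearest neighbour is compound 1, and the step of a 2.6-fold higher number from compound 1 to compound 2 (0.41 log units; beyond the scatter) is modest but beyond the scatter. Compound 3 `O=C(CCCCC[C@H](NC(=O)C1CCNC1=O)C(=O)Nc1ccccc1)NO` has not yet been measured. The change from compound 2 to compound 3 is 2-oxopyrrolidin-3-yl in place of 2-oxopiperidin-3-yl on a carbonyl carbon. Among the measured compounds shown here, no measured step shows a ring contraction of this kind; the only known step, a 2.6-fold higher number from compound 1 to compound 2 (0.41 log units; beyond the scatter), exchanges one lactam arrangement for another while keeping a six-membered ring, so it bears on the present change only indirectly, showing that small alterations in this part of the molecule shift the number modestly. A step of similar or smaller size in this assay is therefore expected, most likely none beyond the scatter, and the expected step is a 1.0-fold lower number from compound 2 to compound 3 (0.00 log units; within the scatter). Compound 3 is thus estimated at 250 nM, with a range from 100 nM to 700 nM.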

Compound 3, half-maximal inhibitory concentration: 118 nM
Estimate against measurement, compound 3: 2.1-fold (0.33 log units) above; the measured number falls inside the stated range.
By their numbers in this assay, from the lowest: compounds 1 and 3 (each within the scatter of the next); then compound 2.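

In this assay, ring size at this place now proves to matter: 2-oxopyrrolidin-3-yl in place of 2-oxopiperidin-3-yl gives a 2.1-fold lower number from compound 2 to compound 3 (0.33 log units; beyond the scatter), a modest step, and the first shown for a ring contraction. The five-membered lactam also stands level with the 6-oxopiperidin-2-yl group of compound 1, with a 1.2-fold higher number from compound 1 to compound 3 (0.09 log units; within the scatter), so among these three compounds a low number does not depend on a six-membered ring. Nothing at hand explains why the two ring sizes differ.

Still open, on these data alone, is whether a seven-membered lactam or a four-membered lactam would continue this order, and whether a plain pyrrolidin-3-yl group, lacking the ring carbonyl, would keep the number. The two mirror forms of the 2-oxopyrrolidin-3-yl group also remain to be told apart, since compound 3 is drawn without a defined ring centre.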